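Cytotoxicity notes on a thiazolylidene hydrazide series

A few compounds are considered here, and "the series" means these few. Any claim that something is new, unique, unknown or untested is made for them only; others in the source may bear on it.

Measured compounds:
- compound 1 `O=C(CSc1ncccn1)N/N=c1/scc(-c2ccccc2)n1-c1ccccc1`: 107 ug/mL
- compound 2 `Cn1cnnc1SCC(=O)N/N=c1/scc(-c2ccccc2)n1-c1ccccc1`: 217 ug/mL
- compound 3 `COc1ccc(-c2cs/c(=N/NC(=O)CSc3ncccn3)n2-c2ccccc2)cc1`: 450 ug/mL

All three were read in an ADME assay on NIH3T3 cells (Mus musculus) for cytotoxicity, read by MTT assay, with a stated time of 24 h; a higher number here means a weaker inhibitor, a lower number a stronger inhibitor. Compound 1 gives 107 ug/mL in this assay, the lowest number of the three. Compound 2 differs from compound 1 by 4-methyl-4H-1,2,4-triazol-3-yl in place of pyrimidin-2-yl on a sulfur. Compound 2 gives 217 ug/mL; the step is a 2.0-fold higher number from compound 1 to compound 2 (0.31 log units; beyond the scatter). Compound 3 differs from compound 1 by methoxy in place of hydrogen on an aromatic carbon. Compound 3 gives 450 ug/mL; the step is a 4.2-fold higher number from compound 1 to compound 3 (0.62 log units; beyond the scatter). Compound 3 therefore stands highest of the three, with both of its steps to the others beyond the scatter.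

Within the data shown here, compound 4 `COc1ccc(-c2cs/c(=N/NC(=O)CSc3nncn3C)n2-c2ccccc2)cc1` has not yet been read in this assay. It differs from compound 3 by 4-methyl-4H-1,2,4-triazol-3-yl in place of pyrimidin-2-yl on a sulfur. Among the measured compounds shown here, this is the same change as the one from compound 1 to compound 2, and in both cases the place is the same, a sulfur whose other neighbours are a saturated chain carbon; the two cores differ by methoxy in place of hydrogen on an aromatic carbon. The change has been seen only once among these compounds, so its transfer onto the core of compound 3 is an assumption rather than an established pattern.

For the measured compounds named here, the step from compound 3 to compound 4 is expected to be a 1.9-fold higher number from compound 3 to compound 4 (0.28 log units; within the scatter), resting on the single earlier step of a 2.0-fold higher number from compound 1 to compound 2 (0.31 log units; beyond the scatter) applied to compound 3 at 450 ug/mL. Compound 4 is thus estimated at 850 ug/mL in this assay, with a range from 450 ug/mL to 1600 ug/mL; since compound 3 already sits at the high end of the series, there is some chance the assay reports only a limit.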

Compound 4, half-maximal inhibitory concentration: 167 ug/mL
Compound 4: middle estimate off by 5.1-fold (0.71 log units), on the high side; measured number below the stated range.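

In this assay the change from pyrimidin-2-yl to 4-methyl-4H-1,2,4-triazol-3-yl on a sulfur does not carry over from the core of compound 1 to the core of compound 3, where it gives a 2.7-fold lower number from compound 3 to compound 4 (0.43 log units; beyond the scatter) and so runs opposite to the earlier step: the same change on two cores in this assay, a 2.0-fold higher number (0.31 log units; beyond the scatter) from compound 1 to compound 2 and a 2.7-fold lower number (0.43 log units; beyond the scatter) from compound 3 to compound 4, 5.5-fold (0.74 log units) apart, beyond the scatter of two such steps.

Read the other way round, methoxy in place of hydrogen on an aromatic carbon gives a 1.3-fold lower number from compound 2 to compound 4 (0.11 log units; within the scatter) on the triazole-bearing core, a step within the scatter, whereas the same change raised the number on the pyrimidine-bearing core: the same change on two cores in this assay, a 4.2-fold higher number (0.62 log units; beyond the scatter) from compound 1 to compound 3 and a 1.3-fold lower number (0.11 log units; within the scatter) from compound 2 to compound 4, 5.5-fold (0.74 log units) apart, beyond the scatter of two such steps.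

Among these compounds, the four compounds therefore show that neither change has a fixed size across these cores and that the two changes do not simply add, but they do not show why, and with each change seen on only two cores they cannot tell which of the steps is the more typical.

Still open, on these data alone, is whether other groups on the sulfur, such as a pyridin-2-yl ring or a plain methyl, follow compound 2 and compound 4 or follow compound 1 and compound 3. Also open, as far as these compounds go, is whether a chlorine or a hydroxyl in place of the methoxy, or a longer chain between the sulfur and the carbonyl, would give the same reversal.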